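Indole nitrogen branching in 5-alpha-reductase inhibitor series

The compounds below may be only part of what the source reports. "The series", "measured", "known", "first", "only" and "open" are said of these compounds alone.

Measured so far in an assay on Prostate gland for inhibition of steroid 5-alpha-reductase (Rattus norvegicus); on this read-out lower numbers stand for stronger inhibition and higher numbers for weaker inhibition:
Compound 1 `CCCCCCn1ccc2cc(/C(C)=C/C(=O)Nc3ccccc3OCCCC(=O)O)ccc21` gives 77 nM.
Compound 2 `C/C(=C\C(=O)Nc1ccccc1OCCCC(=O)O)c1ccc2c(ccn2CC(C)C)c1` gives 160 nM.
Compound 3 `CCCCCC(c1ccccc1)n1ccc2cc(/C(C)=C/C(=O)Nc3ccccc3OCCCC(=O)O)ccc21` gives 25 nM.

The change of interest, (isopropyl in place of pentyl on a saturated chain carbon bound to an aromatic nitrogen), has one measured instance: a 2.1-fold higher number from compound 1 to compound 2 (0.32 log units; beyond the scatter). Compound 3 differs from compound 1 by phenyl in place of hydrogen on a saturated chain carbon bound to an aromatic nitrogen and a saturated chain carbon, with a 3.1-fold lower number from compound 1 to compound 3 (0.49 log units; beyond the scatter); the two steps combine as a 6.4-fold lower number from compound 2 to compound 3 (0.81 log units; beyond the scatter).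

Compound 4 `C/C(=C\C(=O)Nc1ccccc1OCCCC(=O)O)c1ccc2c(ccn2C(c2ccccc2)C(C)C)c1` carries the same change on the core of compound 3: isopropyl in place of pentyl on a saturated chain carbon bound to an aromatic carbon and an aromatic nitrogen. The place lines differ: in compound 1 the saturated chain carbon is bound to an aromatic nitrogen only, in compound 3 also to an aromatic carbon, so this is the same kind of change, not the same.

For compound 4 the expected step is a 2.2-fold higher number from compound 3 to compound 4 (0.34 log units; beyond the scatter), resting on compound 1 and a 2.1-fold higher number from compound 1 to compound 2 (0.32 log units; beyond the scatter). Compound 4 is estimated at 55 nM, between 25 nM and 130 nM.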

Compound 4, half-maximal inhibitory concentration: 25 nM
Compound 4: the middle estimate sits 2.2-fold (0.34 log units) above what was measured; measured number inside the range.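

In this assay, isopropyl in place of pentyl gives no change at the digits printed from compound 3 to compound 4 (within the scatter), and this step cannot be told apart from the one on the core of compound 1: the same change on two cores in this assay, a 2.1-fold higher number (0.32 log units; beyond the scatter) from compound 1 to compound 2 and no change at the digits printed (within the scatter) from compound 3 to compound 4, 2.1-fold (0.32 log units) apart, within the scatter of two such steps Phenyl in place of hydrogen gives a 6.4-fold lower number from compound 2 to compound 4 (0.81 log units; beyond the scatter), which likewise cannot be told apart from its earlier step: the same change on two cores in this assay, a 3.1-fold lower number (0.49 log units; beyond the scatter) from compound 1 to compound 3 and a 6.4-fold lower number (0.81 log units; beyond the scatter) from compound 2 to compound 4, 2.1-fold (0.32 log units) apart, within the scatter of two such steps With the two changes together, 2-methyl-1-phenylpropyl in place of hexyl gives a 3.1-fold lower number from compound 1 to compound 4 (0.49 log units; beyond the scatter); these two pairs of steps do not show that either change has the same size on every core, and they say nothing about cores beyond those shown.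

Still open, from the compounds shown here alone, is whether cyclohexyl or pyridyl in place of phenyl on the saturated chain carbon bound to an aromatic nitrogen would follow the same steps. Also open, going by these compounds, is whether a chain longer than hexyl would do so.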